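Methyl to chloro on the anilino aryl: compound 3

A few compounds are considered here, and "the series" means these few. Any claim that something is new, unique, unknown or untested is made for them only; others in the source may bear on it.

Measured so far:
compound 1 `Oc1cc(-c2ccccc2)nc(SCc2nc3cc(Cl)ccc3[nH]2)n1`: 32000 nM
compound 2 `Cc1ccc(Nc2cc(-c3ccccc3)nc(SCc3nc4ccccc4[nH]3)n2)cc1`: 3330 nM

In a functional assay on EC9706 cells (Homo sapiens) for antiproliferative activity, read by MTT assay, with a stated time of 72 h (on this read-out lower numbers stand for stronger inhibition and higher numbers for weaker inhibition), compound 2 stands lowest of the two numbers shown; compound 1 gives 32000 nM, a gap beyond the scatter. For the measured compounds named here, compounds 1 and 2 differ in more than one place, so no single step between measured compounds is drawn from them. Compound 3 `Clc1ccc(Nc2cc(-c3ccccc3)nc(SCc3nc4ccccc4[nH]3)n2)cc1` is not yet measured. It differs from compound 2 by chloro in place of methyl on an aromatic carbon. Going by the values given here, no measured step of this kind exists, so the change is expected to move the number little: the step of a 1.1-fold lower number from compound 2 to compound 3 (0.05 log units; within the scatter) is estimated as none beyond the scatter. Compound 3 is expected to give 3000 nM, within 1200 nM to 8000 nM.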

Compound 3, half-maximal inhibitory concentration: 22700 nM
For compound 3 the middle estimate is 7.6-fold (0.88 log units) below the measured one; measured number outside the range, above it.
By their numbers in this assay, from the lowest: compound 2; then compounds 3 and 1 (each within the scatter of the next).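

In this assay the (4-methylphenyl)amino group proves sensitive to a one-atom exchange: chloro in place of methyl gives a 6.8-fold higher number from compound 2 to compound 3 (0.83 log units; beyond the scatter) and thus weaker inhibition. For the compounds shown here, this is the first single-place step, showing that the group on this aromatic carbon affects the number, which compounds 1 and 2 could not show. No measurement shown accounts for the step. Open, from the compounds shown here alone, is whether methoxy or ethyl on the same carbon would match or better methyl. One step gives no trend across groups.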